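A few compounds are considered here, and "the series" means these few. Any claim that something is new, unique, unknown or untested is made for them only; others in the source may bear on it.

Compound 1 `COc1cc(-n2ncnc2-c2ccc(C)cc2)cc(OC)c1OC` is the only one of the three measured compounds that gives a number in a functional assay on Jurkat cells (Homo sapiens) for antiproliferative activity, read by MTT assay, with a stated time of 72 h; a higher number here means a weaker inhibitor, a lower number a stronger inhibitor: compound 1 gives 300 nM. Compound 2 `COc1cc(-c2ncnn2-c2cccc(N)c2)cc(OC)c1OC` reaches only a limit of this assay, namely > 10000 nM. Compound 3 `COc1cc(-c2ncnn2-c2ccc(Cl)cc2)cc(OC)c1OC` likewise stops at a limit in this assay, > 10000 nM. The step that the two limits leave unreadable from compound 2 to compound 3 cannot be read because both values sit at the limit of > 10000 nM in this assay, at which 2 of the 3 values shown sit. Compound 4 `COc1cc(-n2ncnc2-c2ccc(F)cc2)cc(OC)c1OC` differs from compound 1 by fluoro in place of methyl on an aromatic carbon. Among the compounds with values here, no measured step touches this change, so nothing in the data points to a shift in either direction. The expectation for this assay is therefore a step within the scatter, a 1.7-fold higher number from compound 1 to compound 4 (0.22 log units; within the scatter). Compound 4 is estimated at 500 nM, with a likely range from 150 nM to 2000 nM.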

Compound 4, half-maximal inhibitory concentration: > 10000 nM
Compound 4: no number, only a limit; the forecaster's own chance of this, stated with the estimate: 10%; middle value at least 20-fold (1.30 log units) away from the limit.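

Fluoro in place of methyl on this aromatic carbon gives an at least 33-fold higher number from compound 1 to compound 4 (1.52 log units; beyond the scatter) in this assay, the first readable step among the compounds shown. With one heavy atom leaving and one entering, this single change separates a measured number from a limit. The result for compound 4 is a limit and not a number, so the full size of the step stays unknown: the limit of > 10000 nM in this assay, at which 3 of the 4 values shown sit.

From the compounds shown here alone, whether an ethyl, a methoxy or an amine at this place would keep a number in this assay remains open. So does whether any other group can stand in for the methyl.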